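Iodo to bromo swap across two cores

The source may report more compounds than this note shows. Statements on the series, on what has been measured and on what is new or still open speak of the compounds shown alone.

Compound 1 `O=C(O)/C(S)=C/c1ccc(I)cc1` and compound 2 `O=C(O)/C(S)=C/c1ccc(Br)cc1` share a core; in an assay on isolated protein for inhibition of Calpain-1 catalytic subunit (Sus scrofa) (a higher number here means a weaker inhibitor, a lower number a stronger inhibitor), compound 1 gives 5200 nM and compound 2 gives 1500 nM. The change between them is bromo in place of iodo on an aromatic carbon and the step was a 3.5-fold lower number from compound 1 to compound 2 (0.54 log units; beyond the scatter). Compound 3 `O=C(O)/C(S)=C/c1c[nH]c2ccc(I)cc12` carries the same iodo group on a different core; in this assay compound 3 gives 90 nM, the lowest of the three numbers. How the core of compound 3 differs from that of compound 1 is not broken down here. Compound 4 `O=C(O)/C(S)=C/c1c[nH]c2ccc(Br)cc12` is the same kind of change on that core, (bromo in place of iodo on an aromatic carbon), with the halogen now part of a fused or bridged system of two rings, meta to a fused ring and para to a fused ring, rather than para to a group of 6 heavy atoms. A similar step is expected, but with wide bounds because a 3.5-fold lower number from compound 1 to compound 2 (0.54 log units; beyond the scatter) is the only such step shown. The expected step is a 3.0-fold lower number from compound 3 to compound 4 (0.48 log units; beyond the scatter). Compound 4 is expected to give 30 nM in this assay, between 10 nM and 90 nM.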

Compound 4, half-maximal inhibitory concentration: 20 nM
The estimate for compound 4 lay 1.5-fold (0.18 log units) above the measured number, within the range that was stated.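

In this assay, bromo in place of iodo on an aromatic carbon gives a 4.5-fold lower number from compound 3 to compound 4 (0.65 log units; beyond the scatter) on the core of compound 3, so the direction seen on the core of compound 1 recurs. This covers two cores only and does not show that the step would hold on any other core, nor what lies behind it. The size of the step carries over between these two cores: the same change on two cores in this assay, a 3.5-fold lower number (0.54 log units; beyond the scatter) from compound 1 to compound 2 and a 4.5-fold lower number (0.65 log units; beyond the scatter) from compound 3 to compound 4, 1.3-fold (0.11 log units) apart, within the scatter of two such steps

Still open, going by these compounds, is whether chloro, fluoro or a nitrile on the same aromatic carbon would extend the step beyond bromo. Also open, on these data alone, is how a methyl ester in place of the carboxylic acid would affect the number on either core.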